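Phenyl for Methyl on a Pyrazolopyridinone Core

The source may report more compounds than this note shows. Statements on the series, on what has been measured and on what is new or still open speak of the compounds shown alone.

Measured compounds in an assay on isolated protein for inhibition of protein kinase C zeta type (Homo sapiens), read by mobility shift assay, tested at 30 uM; a lower number here means less inhibition, a higher number more inhibition at the concentration tested (going by the name of the read-out):
compound 1 `Cc1cc2[nH]nc(N)c2c(=O)[nH]1`, 10%
compound 2 `Nc1n[nH]c2cc(-c3ccncc3)[nH]c(=O)c12`, 10%
compound 3 `Cc1cc2c(c(N)nn2C)c(=O)[nH]1`, 0%

Among the compounds with values here, compound 3 shows the smallest of the three numbers in this assay, yet the only measured step, a number 10 percentage points lower from compound 1 to compound 3 (within the scatter), lies within the scatter, and compound 2 lies the same distance away, so all three sit within the scatter of one another. Compound 4 `Cn1nc(N)c2c(=O)[nH]c(-c3ccccc3)cc21` has not been measured; it differs from compound 3 by phenyl in place of methyl on an aromatic carbon.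

Within the data shown here, no measured step matches this change exactly. The only step shown, a number 10 percentage points lower from compound 1 to compound 3 (within the scatter), concerns a methyl on an aromatic nitrogen and lies within the scatter. Compound 1 and compound 2 differ in that compound 2 carries an aromatic ring where compound 1 carries a methyl, and their two values are equal, which suggests that an aromatic ring at that spot does not move the number. Compound 4 is therefore expected to show no step beyond the scatter, a number 5 percentage points higher from compound 3 to compound 4 (within the scatter). Compound 4 is estimated at 5%, within -10% to 20%.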

Compound 4, a percentage reported as inhibition, at one concentration (the size of the read-out at that concentration, not a potency): 6%
Estimate against measurement, compound 4: 1 percentage points below, within the range that was stated.
By their numbers in this assay, from the lowest: compounds 3, 4, 1 and 2 (each within the scatter of the next).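

With the methyl on the aromatic nitrogen held in place, this assay gives a number 6 percentage points higher from compound 3 to compound 4 (within the scatter) when phenyl replaces methyl on the aromatic carbon next to the ring nitrogen. Within the data shown here, this is the first direct reading of this change at this position, and it shows that a six-membered aromatic ring of carbon only can stand there without a shift beyond the scatter. No measurement at hand offers an explanation for this reading.

All four compounds remain within the scatter of their neighbours, so the compounds shown do not reveal any group at this position that clearly changes the number. On these data alone, whether an amine, a carboxylic acid or a longer chain on this aromatic carbon would move it beyond the scatter remains open.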